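Trifluoromethyl in Place of Hydroxy on a Shared Core

The compounds below may be only part of what the source reports. "The series", "measured", "known", "first", "only" and "open" are said of these compounds alone.

Values in a functional assay on SW-620 cells (Homo sapiens) for inhibition, read by MTT assay, with a stated time of 72 h; a higher number here means a weaker inhibitor, a lower number a stronger inhibitor:
Compound 1 `COc1cc(NC(C)CCCNC(=O)NNC(=O)Nc2ccc(Br)cc2)c2ncccc2c1`: 17000 nM
Compound 2 `COc1cc(NC(C)CCCNC(=O)Nc2ccc(C(F)(F)F)cc2)c2ncccc2c1`: 22000 nM
Compound 3 `COc1cc(NC(C)CCCNC(=O)Nc2cccc(O)c2)c2ncccc2c1`: 27000 nM

Compound 3 has the highest of the three numbers, yet its steps to the others stay within the scatter: a 1.2-fold higher number from compound 2 to compound 3 (0.09 log units; within the scatter) and a 1.6-fold higher number from compound 1 to compound 3 (0.20 log units; within the scatter). Compound 4 `COc1cc(NC(C)CCCNC(=O)Nc2cccc(C(F)(F)F)c2)c2ncccc2c1` has not been measured. It differs from compound 3 in one place: trifluoromethyl in place of hydroxy on an aromatic carbon. The step that bears on this is a 1.2-fold higher number from compound 2 to compound 3 (0.09 log units; within the scatter), where 4-(trifluoromethyl)phenyl gave way to 3-hydroxyphenyl; compound 4 instead carries 3-(trifluoromethyl)phenyl, so the comparison is close but not exact. A step no larger than the scatter is therefore expected, and in this assay the expected step is a 1.2-fold lower number from compound 3 to compound 4 (0.09 log units; within the scatter). Compound 4 is estimated at 22000 nM, with a range from 10000 nM to 50000 nM.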

Compound 4, half-maximal inhibitory concentration: 22000 nM
Beside the measured number, compound 4's estimate shows no gap at the digits printed; the measured number falls inside the stated range.
By their numbers in this assay, from the lowest: compounds 1, 2, 4 and 3 (each within the scatter of the next).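

In this assay, trifluoromethyl in place of hydroxy gives a 1.2-fold lower number from compound 3 to compound 4 (0.09 log units; within the scatter) and thus stays within the scatter, even though the hydrogen-bond donor and acceptor of hydroxy are gone. Moving trifluoromethyl from 4-(trifluoromethyl)phenyl to 3-(trifluoromethyl)phenyl gives no change at the digits printed from compound 2 to compound 4 (within the scatter) here, so these two placements cannot be told apart. The larger replacement also stays small, with a 1.3-fold higher number from compound 1 to compound 4 (0.11 log units; within the scatter) on the same shared core. On these data alone, whether an amine or a carboxylic acid on this aromatic carbon would give a step beyond the scatter remains open. No supporting evidence is available to explain why these steps stay so small.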